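Aryl substituent survey on a bis-phenol triazole series

The compounds below may be only part of what the source reports. "The series", "measured", "known", "first", "only" and "open" are said of these compounds alone.

Measured compounds:
compound 1 `Cc1ccc(-n2nc(-c3ccc(C(F)(F)F)cc3O)nc2-c2ccccc2O)cc1` gives 102% in a functional assay on PC-12 cells (Rattus norvegicus) for cytotoxicity, read by MTT assay, with stated times of 2 h and 24 h, tested at 10 uM; on this read-out higher numbers stand for a stronger effect at the one concentration tested and lower numbers for a weaker effect
compound 2 `CCc1ccc(-n2nc(-c3ccc(C(F)(F)F)cc3O)nc2-c2ccccc2O)cc1` gives 107% in this assay
compound 3 `CC(C)(C)c1ccc(-n2nc(-c3ccc(C(F)(F)F)cc3O)nc2-c2ccccc2O)cc1` gives 81.1% in this assay

Compound 3 stands lowest of the three numbers in this assay. Its nearest neighbour is compound 1, and a number 20.9 percentage points lower from compound 1 to compound 3 (beyond the scatter); the gap to compound 2 is wider, as a number 25.9 percentage points lower from compound 2 to compound 3 (beyond the scatter). Compound 1 and compound 2 sit within the scatter of each other, since a number 5 percentage points higher from compound 1 to compound 2 (within the scatter), so no order between them is claimed.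

The next compound, compound 4 `Oc1cc(C(F)(F)F)ccc1-c1nc(-c2ccccc2O)n(-c2ccc(Cl)cc2)n1`, differs from compound 3 in one place: chloro in place of tert-butyl on an aromatic carbon. Among the compounds with values here, no measured step involves chloro, so the only bearing comes from the two steps in which tert-butyl enters: both lowered the number by a modest, beyond-scatter amount relative to the one-carbon and two-carbon substituents. Chloro, with a single heavy atom, is taken here as nearer to those substituents than to tert-butyl in what it brings to the ring, so the expectation is a modest rise back toward the region occupied by compound 1 and compound 2, with a number 14.9 percentage points higher from compound 3 to compound 4 (beyond the scatter) expected.

Compound 4 is therefore estimated at 96%, in the range 80% to 110%.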

Compound 4, a percentage reported as activity, at one concentration (the size of the read-out at that concentration, not a potency): 96.1%
For compound 4 the middle estimate is 0.1 percentage points below the measured one; low and high end bracket the measured number.
By their numbers in this assay, from the lowest: compound 3; then compounds 4, 1 and 2 (each within the scatter of the next, the first and the last beyond it).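

On the aromatic carbon para to a large group, the change from 4-(tert-butyl)phenyl to 4-chlorophenyl gives a number 15 percentage points higher from compound 3 to compound 4 (beyond the scatter) in this assay and leaves compound 3 as the only one of the four set apart at the low end, with its steps to the other three all beyond the scatter. Chloro is also the first group in the series that is not an alkyl group, and a carbon substituent at this place is clearly not needed for the high reading: with methyl leaving the step reads a number 5.9 percentage points lower from compound 1 to compound 4 (within the scatter) and with ethyl leaving it reads a number 10.9 percentage points lower from compound 2 to compound 4 (beyond the scatter), so chloro stays with one alkyl neighbour and separates from the other, even though methyl and ethyl cannot be ordered against each other. Among these four groups the lower reading goes with tert-butyl alone, and no measured evidence bears on what lies behind it.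

On these data alone, whether an isopropyl group, a methoxy group, a fluoro group or an amine at the same place would read with compound 3 or with compound 1 stays open. Also open, as far as these compounds go, is whether the two hydroxyl groups and the trifluoromethyl group of the shared core matter for the reading at all, and a single concentration says nothing about potency.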